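The source may hold more compounds than are shown below. What is called first, only, known or untested is meant among the compounds shown, and "the series" means these compounds.

Measured so far in an ADME assay on MT4 cells (Homo sapiens) for cytotoxicity, read by MTT assay, with a stated time of 4 days; a lower number here means that less compound is tolerated, a higher number that more compound is tolerated:

Compound 1, `CCOC(=O)c1cnc(N2CCN(Cc3ccc(C#N)cc3)CC2)nc1Oc1c(C)cc(-c2ccc(C#N)cc2)cc1C`. In this assay compound 1 gives > 125000 nM, which is a limit of the assay and not a number.
Compound 2, `CCOC(=O)c1cnc(N2CCN(Cc3ccccc3C(F)(F)F)CC2)nc1Oc1c(C)cc(-c2ccc(C#N)cc2)cc1C`. In this assay compound 2 gives > 125000 nM, again a limit of the assay.

Compound 2 therefore stands at the upper edge of what this assay reports: the limit of > 125000 nM in this assay, at which 2 of the 2 values shown sit. Among the compounds with values here, the one step with measured ends, a step that the two limits leave unreadable from compound 1 to compound 2, cannot be read in size or direction, since both ends are limits.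

Compound 3, `CCOC(=O)c1cnc(N2CCN(Cc3ccc(F)cc3)CC2)nc1Oc1c(C)cc(-c2ccc(C#N)cc2)cc1C`, differs from compound 2 in one place: 4-fluorophenyl in place of 2-(trifluoromethyl)phenyl on a saturated chain carbon bound to an amine nitrogen in a ring. Within the data shown here, the only measured step, from compound 1 to compound 2, exchanged a substituent at the same place and left the value at the limit both times, so it gives no readable size to carry over. For compound 3 the expectation is accordingly that this assay again returns only a limit, with an estimated step that the limit leaves unreadable from compound 2 to compound 3 that should not exceed the scatter. The estimate for compound 3 is 150000 nM, within 50000 nM to 300000 nM.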

Compound 3, half-maximal cytotoxic concentration: > 117000 nM
Compound 3: no number, only a limit (the forecaster's own chance of this, stated with the estimate: 80%); the middle value does not contradict the limit.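

In this assay compound 3 gives > 117000 nM, a limit of the assay and not a number. Within the data shown here, compound 1 and compound 2 also stand at limits, so no step among the three compounds can be read. The compounds shown leave open whether any substituent change on the benzyl group gives a readable value in this assay.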